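The compounds below may be only part of what the source reports. "The series", "measured", "known", "first", "only" and "open" are said of these compounds alone.

Compound 1 `Cc1cc(O)c(C2=NN(c3ccc(S(N)(=O)=O)cc3)C(c3ccccc3O)C2)cc1Cl` gives 73.6%
Compound 2 `Cc1cc(O)c(C2=NN(c3ccc(S(N)(=O)=O)cc3)C(c3ccc(Cl)cc3)C2)cc1Cl` gives 65.8%
Compound 3 `Cc1cc(O)c(C2=NN(c3ccc(S(N)(=O)=O)cc3)C(/C=C/c3ccccc3)C2)cc1Cl` gives 78.9%

These three share a core and differ only in the group on one saturated ring carbon, measured in a functional assay on the whole organism (strain Wistar) for inhibition, with Rattus norvegicus as the target, read by paw edema, with stated times of 30 min and 3 h, at a dose of 20 mg/kg by the oral route; on this read-out higher numbers stand for more inhibition at the one dose given (going by the name of the read-out) and lower numbers for less inhibition. Among the compounds with values here, compound 3 shows the highest of the three numbers; the step of a number 5.3 percentage points higher from compound 1 to compound 3 (within the scatter) is small, while a number 13.1 percentage points higher from compound 2 to compound 3 (beyond the scatter) is the only step beyond the scatter. Compound 4 `COc1ccc(C2CC(c3cc(Cl)c(C)cc3O)=NN2c2ccc(S(N)(=O)=O)cc2)cc1OC` carries the change (3,4-dimethoxyphenyl in place of 2-phenylethenyl on a saturated ring carbon). Two earlier steps bear on it: a number 7.8 percentage points lower from compound 1 to compound 2 (within the scatter) shows that swapping one aromatic group for another changes little, and a number 13.1 percentage points higher from compound 2 to compound 3 (beyond the scatter) shows that moving from an aromatic group to the 2-phenylethenyl group gave a modest gain. Reversing that, a modest drop is expected, a number 8.9 percentage points lower from compound 3 to compound 4 (within the scatter). Compound 4 is therefore estimated at 70%, between 60% and 80%.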

Compound 4, a percentage reported as inhibition, in the whole organism at one dose (the size of the read-out at that dose, not a potency): 60.5%
The estimate for compound 4 lay 9.5 percentage points above the measured number, within the range that was stated.
By their numbers in this assay, from the lowest: compounds 4, 2, 1 and 3 (each within the scatter of the next, the first and the last beyond it).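

Replacing 2-phenylethenyl with 3,4-dimethoxyphenyl costs more here than any earlier step at this position (a number 18.4 percentage points lower from compound 3 to compound 4 (beyond the scatter)), so the larger group with two oxygen atoms gives no gain. Aromatic groups at this position are also not all equivalent: the step to 3,4-dimethoxyphenyl from 2-hydroxyphenyl passes the scatter (a number 13.1 percentage points lower from compound 1 to compound 4 (beyond the scatter)), whereas the one from 4-chlorophenyl does not (a number 5.3 percentage points lower from compound 2 to compound 4 (within the scatter)). Nothing available explains these differences. Still open, going by these compounds, is how an unsubstituted phenyl, a simple amine or a carboxylic acid would behave at this position.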